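A few compounds are considered here, and "the series" means these few. Any claim that something is new, unique, unknown or untested is made for them only; others in the source may bear on it.

Of the compounds shown here, two sharing one core have been measured in a functional assay on DU-145 cells (Homo sapiens) for cytotoxicity, read by MTT assay; on this read-out lower numbers stand for stronger inhibition and higher numbers for weaker inhibition. Compound 1 (`CC(=O)OCCC(=O)O[C@H](CC=C(C)C)C1=CC(=O)c2c(O)ccc(O)c2C1=O`) gives 15700 nM, and compound 2 (`CCCCC(CC(=O)O[C@H](CC=C(C)C)C1=CC(=O)c2c(O)ccc(O)c2C1=O)OC(C)=O`) gives 67700 nM, the higher of the two numbers and so the weaker inhibition. Within the data shown here, the only measured step, a 4.3-fold higher number from compound 1 to compound 2 (0.63 log units; beyond the scatter), is modest and comes with butyl in place of hydrogen on a saturated chain carbon.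

Compound 3 (`CC(C)=CC[C@@H](OC(=O)CC(O)c1ccccc1)C1=CC(=O)c2c(O)ccc(O)c2C1=O`) has not yet been measured. It differs from compound 2 as follows: hydroxy(phenyl)methyl in place of 1-acetoxypentyl on a saturated chain carbon bound to a carbonyl carbon. In words, hydroxy(phenyl)methyl stands in place of 1-acetoxypentyl on a saturated chain carbon bound to a carbonyl carbon. Among the measured compounds shown here, this change removes the group that carries the butyl of the measured step, but it also brings in an aromatic ring, and no measured compound shows what such a ring does here. The expectation therefore leans on compound 1, which lacks that butyl and gives 15700 nM. In this assay a modest move towards stronger inhibition is expected, a 2.7-fold lower number from compound 2 to compound 3 (0.43 log units; beyond the scatter). For compound 3 the estimated value is 25000 nM, with an expected range of 8000 nM to 70000 nM.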

Compound 3, half-maximal inhibitory concentration: 17000 nM
Compound 3: middle estimate off by 1.5-fold (0.17 log units), on the high side; the range from low to high includes it.
By their numbers in this assay, from the lowest: compounds 1 and 3 (each within the scatter of the next); then compound 2.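

In this assay, hydroxy(phenyl)methyl in place of 1-acetoxypentyl on this saturated chain carbon bound to a carbonyl carbon gives a 4.0-fold lower number from compound 2 to compound 3 (0.60 log units; beyond the scatter), so this position can carry an aromatic ring without the weaker inhibition seen with the 1-acetoxypentyl group. Set against the acetoxymethyl group of compound 1, the same hydroxy(phenyl)methyl group gives a 1.1-fold higher number from compound 1 to compound 3 (0.03 log units; within the scatter), which leaves the two groups indistinguishable on this read-out even though they differ in size and one of them brings in a ring. Of the three compounds, only compound 2 stands apart from the other two, and it is the weakest of them here. Nothing at hand explains these numbers.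

In hydroxy(phenyl)methyl the aromatic ring and the hydroxy enter together, so the compounds shown do not separate what each one contributes. They also do not tell what a benzyl group without the hydroxy, an amine or a carboxylic acid would give at this place.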